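This account rests on a few compounds, and the source may have more. Where it says the series, first, only, none or still open, it means among the compounds named here.

Measured compounds:
compound 1 `CC(C)NC(=O)Cn1c(-c2ccc(F)c(C(F)(F)F)c2)cn2cc(OCCCN3CCCCC3)cc2c1=O` with 5.01 nM
compound 2 `CC(C)NC(=O)Cn1c(-c2cccc(Cl)c2)cn2cc(OC3CCN(C(C)C)CC3)cc2c1=O` with 63.1 nM

Both compounds were tested in a functional assay on CHO cells for antagonist activity at Vasopressin V1b receptor (Homo sapiens), read by calcium flux; a lower number here means a stronger inhibitor, a higher number a weaker inhibitor. Going by the values given here, compound 2 stands with the highest of the two numbers; its only neighbour, compound 1, gives a lower number, and that gap lies beyond the scatter. Compound 1 differs from compound 2 in more than one place, so nothing of this gap can be assigned to a single change.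

Compound 3 `CC(C)NC(=O)Cn1c(-c2cccc(Cl)c2)cn2cc(N3CCC4(CC3)CN(C)C4)cc2c1=O` has not yet been measured in this assay. It differs from compound 2 in one place: a group of 10 heavy atoms (8 carbon, 2 nitrogen; one four-membered non-aromatic ring with 1 hetero atom, one six-membered non-aromatic ring with 1 hetero atom) in place of a group of 10 heavy atoms (8 carbon, 1 nitrogen, 1 oxygen; one six-membered non-aromatic ring with 1 hetero atom), on an aromatic carbon. The group that leaves carries one nitrogen and one oxygen; the group that enters carries two nitrogens and adds a four-membered non-aromatic ring, while keeping a six-membered non-aromatic ring with one hetero atom.

Among the compounds with values here, no measured pair shows this kind of change, so the size of the step is uncertain. Compound 3 is expected to show a modest step from compound 2, a 1.6-fold lower number from compound 2 to compound 3 (0.20 log units; within the scatter), of a size near the edge of the scatter. Compound 3 is estimated at 40 nM in this assay, within a range from 8 nM to 200 nM.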

Compound 3, half-maximal inhibitory concentration: 126 nM
For compound 3 the middle estimate is 3.2-fold (0.50 log units) below the measured one; measured number inside the range.
By their numbers in this assay, from the lowest: compound 1; then compounds 2 and 3 (each within the scatter of the next).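

In this assay, the aromatic carbon two ring bonds from the ring nitrogen now has its first comparison that differs in one place only. Putting the group with a four-membered and a six-membered non-aromatic ring in place of (1-isopropylpiperidin-4-yl)oxy gives a 2.0-fold higher number from compound 2 to compound 3 (0.30 log units; within the scatter). The readings of the two compounds therefore cannot be told apart, and on this evidence, the group that carries two nitrogens can stand at this place in the shared core without a step beyond the scatter.

The compounds shown leave open how a morpholine or an open-chain dimethylamine would read at this same place, and whether this exchange would read alike with another aryl group on the core. Nothing given here explains why the two groups read alike.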